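This account rests on a few compounds, and the source may have more. Where it says the series, first, only, none or still open, it means among the compounds named here.

Measured compounds:
- Compound 1, `C[C@H]1CC[C@@H]2[C@@H](OC(=O)[C@]23CC(c2ccccc2Br)=NO3)[C@]2(C)C(=O)C=C[C@@]12O`, in a functional assay on SW-620 cells (Homo sapiens) for cytotoxicity, read by sulforhodamine B assay, with a stated time of 48 h (on this read-out higher numbers stand for weaker inhibition and lower numbers for stronger inhibition), gives 44000 nM.
- Compound 2, `C[C@H]1CC[C@@H]2[C@@H](OC(=O)[C@]23CC(c2ccc([N+](=O)[O-])cc2)=NO3)[C@]2(C)C(=O)C=C[C@@]12O`, in this assay gives 9000 nM.
- Compound 3, `Cc1cccc(C2=NO[C@]3(C2)C(=O)O[C@@H]2[C@H]3CC[C@H](C)[C@]3(O)C=CC(=O)[C@@]23C)c1`, in this assay gives 15000 nM.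

Among these three, compound 1 carries the highest number, with a 2.9-fold lower number from compound 1 to compound 3 (0.47 log units; beyond the scatter) and a 4.9-fold lower number from compound 1 to compound 2 (0.69 log units; beyond the scatter) both beyond the scatter, so it is the weakest of the measured set. Compound 4, `C[C@H]1CC[C@@H]2[C@@H](OC(=O)[C@]23CC(c2ccc(F)cc2)=NO3)[C@]2(C)C(=O)C=C[C@@]12O`, differs from compound 1 by 4-fluorophenyl in place of 2-bromophenyl on a carbon with a double bond to nitrogen. The two measured steps that bear on this change both replace the same 2-bromophenyl with a different aromatic ring and both lower the number: a 4.9-fold lower number from compound 1 to compound 2 (0.69 log units; beyond the scatter) and a 2.9-fold lower number from compound 1 to compound 3 (0.47 log units; beyond the scatter). A modest step in the same direction is therefore expected for compound 4, about a 2.9-fold lower number from compound 1 to compound 4 (0.47 log units; beyond the scatter). Compound 4 is expected to give 15000 nM, with a range from 6000 nM to 40000 nM.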

Compound 4, half-maximal inhibitory concentration: 3600 nM
Beside the measured number, compound 4's estimate is 4.2-fold (0.62 log units) above it; the measured number lies below the stated range.
By their numbers in this assay, from the lowest: compound 4; then compounds 2 and 3 (each within the scatter of the next); then compound 1.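

In this assay, 4-fluorophenyl gives the largest step yet seen at this position, a 12-fold lower number from compound 1 to compound 4 (1.09 log units; beyond the scatter). For the compounds shown here, it also outdoes both other rings, with a 4.2-fold lower number from compound 3 to compound 4 (0.62 log units; beyond the scatter) and a 2.5-fold lower number from compound 2 to compound 4 (0.40 log units; beyond the scatter), so compound 4 is the strongest of the four and the choice of aromatic ring matters more than the earlier compounds showed. Nothing available explains this result. On these data alone, the step from 2-bromophenyl changes both the halogen and its place on the ring, so which of the two counts stays open. As far as these compounds go, whether 2-fluorophenyl, 4-chlorophenyl or a phenyl ring bearing an amine would match 4-fluorophenyl also stays open.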